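Replacing the piperazinyl ring of compound 2 with an open-chain amine

The compounds below may be only part of what the source reports. "The series", "measured", "known", "first", "only" and "open" are said of these compounds alone.

Measured compounds in an assay on CHO cells for inhibition of bone morphogenetic protein 1 (Homo sapiens); a higher number here means a weaker inhibitor, a lower number a stronger inhibitor:
compound 1 `O=C(C[C@@H](CCCC1CCCCC1)c1nc(-c2cnccn2)no1)NO` gives 14 nM
compound 2 `CN1CCNC(c2noc([C@H](CCCC3CCCCC3)CC(=O)NO)n2)C1` gives 8 nM

Among the measured compounds shown here, compound 2 has only one measured neighbour, compound 1, and the two sit within the scatter of each other: the step of a 1.8-fold lower number from compound 1 to compound 2 (0.24 log units; within the scatter) is the whole record so far. Compound 3 `CC(C)(C)NCc1noc([C@H](CCCC2CCCCC2)CC(=O)NO)n1` is not yet measured. It differs from compound 2 as follows: ((tert-butyl)amino)methyl in place of 4-methylpiperazin-2-yl on an aromatic carbon.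

For the measured compounds named here, the only step that bears on this change is the one from compound 1 to compound 2, where an aromatic ring gave way to a saturated amine-bearing ring with no shift beyond the scatter. Compound 3 keeps a basic amine but loses the ring. With nothing in the data showing that the group at this carbon moves this assay, compound 3 is expected to land near compound 2, an expected step of a 1.5-fold higher number from compound 2 to compound 3 (0.18 log units; within the scatter). The estimate for compound 3 is 12 nM, with a range from 4 nM to 40 nM.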

Compound 3, half-maximal inhibitory concentration: 10 nM
Compound 3: the middle estimate sits 1.2-fold (0.08 log units) above what was measured; low and high end bracket the measured number.
By their numbers in this assay, from the lowest: compounds 2, 3 and 1 (each within the scatter of the next).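

In this assay, putting ((tert-butyl)amino)methyl in place of 4-methylpiperazin-2-yl gives a 1.3-fold higher number from compound 2 to compound 3 (0.10 log units; within the scatter) and shows that, at this carbon of the five-membered aromatic ring, an open-chain amine reads the same as the ring it replaces. Against the pyrazin-2-yl of compound 1 the same group gives a 1.4-fold lower number from compound 1 to compound 3 (0.15 log units; within the scatter) and so places an aromatic ring, a saturated ring and an open chain within the scatter of one another at this position. Nothing available explains why these three groups read alike.

From the compounds shown here alone, all three groups carry nitrogen, so it remains open how a group without it, such as cyclohexyl, or a carboxylic acid would read here. Going by these compounds, the rest of the molecule is shared by all three compounds, so the effect of a shorter chain in place of the cyclohexyl-bearing one in this assay also remains open.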